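Two analogs at the assay limit, a third awaits

The source may report more compounds than this note shows. Statements on the series, on what has been measured and on what is new or still open speak of the compounds shown alone.

compound 1, `N#CC1=C(N)Oc2c(N)cc3nc4ccccc4nc3c2C12C(=O)N(Cc1cnnn1-c1cccc(Br)c1)c1ccccc12`, in a functional assay on MCF7 cells (Homo sapiens) for antiproliferative activity, read by MTT assay, with a stated time of 48 h; a lower number here means a stronger inhibitor, a higher number a weaker inhibitor: > 50000 nM, a limit of the assay
compound 2, `Cc1ccc(-n2nncc2CN2C(=O)C3(C(C#N)=C(N)Oc4c(N)cc5nc6ccccc6nc5c43)c3ccccc32)cc1C`, in this assay: > 50000 nM, a limit of the assay

Compound 1 and compound 2 share their core and differ only in the aryl group on an aromatic nitrogen. The step that the two limits leave unreadable from compound 1 to compound 2 cannot be read, since both values are limits. Compound 2 thus stands at the limit of this assay, and so does compound 1 (the limit of > 50000 nM in this assay, at which 2 of the 2 values shown sit). Compound 3, `CCc1cccc(CC)c1-n1nncc1CN1C(=O)C2(C(C#N)=C(N)Oc3c(N)cc4nc5ccccc5nc4c32)c2ccccc21`, carries a change of the same kind: 2,6-diethylphenyl in place of 3,4-dimethylphenyl on an aromatic nitrogen. Within the data shown here, the only measured step bearing on it is a step that the two limits leave unreadable from compound 1 to compound 2, which yields neither a size nor a direction. Because both measured values sit at the limit (the limit of > 50000 nM in this assay, at which 2 of the 2 values shown sit), compound 3 is expected to reach only that limit as well. Compound 3 is therefore estimated at 50000 nM, within 20000 nM to 120000 nM. This estimate means an expected step of a number no higher from compound 2 to compound 3 (the limit leaves the size open), none beyond the scatter.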

Compound 3, half-maximal inhibitory concentration: > 50000 nM
Compound 3: only a limit was reported; the forecaster's own chance of this, stated with the estimate: 85%; the middle value sits exactly at the limit.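

Compound 3 sits at the same limit as compound 1 and compound 2, so neither of its steps to those two compounds can be read in this assay: the limit of > 50000 nM in this assay, at which 3 of the 3 values shown sit.

The compounds shown leave open how these three aryl groups rank against one another, and whether any group at this place gives a value inside the range of the assay.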